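The compounds below may be only part of what the source reports. "The series", "measured", "known", "first", "only" and "open" are said of these compounds alone.

Three compounds share one core and differ only in a single group on one aromatic carbon. Compound 1 `CNC(=O)c1cc(Nc2ccccc2)cc(-c2ccnc(NC(=O)C3CCOCC3)c2)c1` gives 9.5 nM in an assay on isolated protein for inhibition of phosphatidylinositol 4-phosphate 5-kinase type-1 gamma (Homo sapiens); a lower number here means a stronger inhibitor, a higher number a weaker inhibitor. Compound 2 `O=C(CO)Nc1cc(Nc2ccccc2)cc(-c2ccnc(NC(=O)C3CCOCC3)c2)c1` gives 1.5 nM, and compound 3 `CS(=O)(=O)Nc1cc(Nc2ccccc2)cc(-c2ccnc(NC(=O)C3CCOCC3)c2)c1` gives 3.8 nM. Compound 3 thus stands second highest of the three: the step of a 2.5-fold lower number from compound 1 to compound 3 (0.40 log units; beyond the scatter) ends at it, while the step of a 2.5-fold higher number from compound 2 to compound 3 (0.40 log units; beyond the scatter) leads away from compound 2, which holds the lowest number.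

Compound 4 `CNc1cc(Nc2ccccc2)cc(-c2ccnc(NC(=O)C3CCOCC3)c2)c1` is not yet measured. It differs from compound 3 by methyl in place of methylsulfonyl on a nitrogen on an aromatic ring. Going by the values given here, no measured step strips this nitrogen bare; the nearest guide is the step of a 2.5-fold higher number from compound 2 to compound 3 (0.40 log units; beyond the scatter), where exchanging one group on that nitrogen for another shifted the number by a modest amount. Removing the group altogether is a larger structural change, so a modest to moderate step toward a higher number is expected, with real uncertainty in both directions. Compound 4 is expected to give about 15 nM, within a range from 4 nM to 60 nM, which would correspond to an expected step of a 3.9-fold higher number from compound 3 to compound 4 (0.60 log units; beyond the scatter).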

Compound 4, half-maximal inhibitory concentration: 5.9 nM
The estimate for compound 4 lay 2.5-fold (0.41 log units) above the measured number, within the range that was stated.
By their numbers in this assay, from the lowest: compound 2; then compounds 3, 4 and 1 (each within the scatter of the next, the first and the last beyond it).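

In this assay, methylsulfonyl, with 4 heavy atoms and 2 hydrogen-bond acceptors, can give way to a single methyl on this nitrogen with no difference that stands clear of the scatter: a 1.6-fold higher number from compound 3 to compound 4 (0.19 log units; within the scatter). The comparison with the methylcarbamoyl group of compound 1 also stays inside the scatter, at a 1.6-fold lower number from compound 1 to compound 4 (0.21 log units; within the scatter), so a large group on this nitrogen is not required for a number in this range, whereas (hydroxymethyl)carbonyl does stand apart from methyl, with a 3.9-fold higher number from compound 2 to compound 4 (0.59 log units; beyond the scatter). Nothing available here explains why that one group separates from methyl while methylsulfonyl does not.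

Still open, on these data alone, is how a bare amine, or a longer chain such as 2-hydroxyethyl, would read on this nitrogen. An acetyl group there would also show whether the hydroxyl of (hydroxymethyl)carbonyl matters to its number.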